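A few compounds are considered here, and "the series" means these few. Any claim that something is new, unique, unknown or untested is made for them only; others in the source may bear on it.

Compound 1 `COc1cc2c(cc1NS(=O)(=O)c1cccc(Cl)c1Cl)[nH]c(=O)n2C(C)C` and compound 2 `COc1cc2c(cc1NS(=O)(=O)c1cccc(Cl)c1Cl)[nH]c(=O)n2CCN(C)C` share one core and differ only in the group carried on the aromatic nitrogen. In a functional assay on CHO cells for antagonist activity at C-C chemokine receptor type 4 (Homo sapiens), read by radioligand binding and GTPgammaS binding (on this read-out higher numbers stand for weaker inhibition and lower numbers for stronger inhibition), compound 1 gives 1000 nM, and in this assay compound 2 gives 2000 nM. The step of a 2.0-fold higher number from compound 1 to compound 2 (0.30 log units; within the scatter) is the only one measured so far, and it leaves compound 2 standing within the scatter of compound 1 on the numbers shown, so nothing can be said about which of the two inhibits more strongly.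

Compound 3 `COc1cc2c(cc1NS(=O)(=O)c1cccc(Cl)c1Cl)[nH]c(=O)n2C(CO)CO` is the next compound in this series, and it differs from compound 2 by 2-hydroxy-1-(hydroxymethyl)ethyl in place of 2-(dimethylamino)ethyl on an aromatic nitrogen. Within the data shown here, the one measured step that bears on this change is the exchange at the same aromatic nitrogen, a 2.0-fold higher number from compound 1 to compound 2 (0.30 log units; within the scatter), which stayed within the scatter. On that basis compound 3 is expected to show no step beyond the scatter in this assay, an estimated 1.3-fold lower number from compound 2 to compound 3 (0.12 log units; within the scatter). The estimate for compound 3 in this assay is therefore 1500 nM, with a range from 500 nM to 5000 nM.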

Compound 3, half-maximal inhibitory concentration: 1580 nM
Estimate against measurement, compound 3: 1.1-fold (0.02 log units) below; low and high end bracket the measured number.
By their numbers in this assay, from the lowest: compounds 1, 3 and 2 (each within the scatter of the next).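

In this assay, the exchange of 2-(dimethylamino)ethyl for 2-hydroxy-1-(hydroxymethyl)ethyl on the aromatic nitrogen gives a 1.3-fold lower number from compound 2 to compound 3 (0.10 log units; within the scatter), and the exchange of isopropyl for the same group gives a 1.6-fold higher number from compound 1 to compound 3 (0.20 log units; within the scatter), so all three groups stand within the scatter of one another. The earlier pair covered only isopropyl and 2-(dimethylamino)ethyl, whereas this result shows that the position also accepts a group with 2 hydrogen-bond donors and 2 hydrogen-bond acceptors in place of one with 0 hydrogen-bond donors and 1 hydrogen-bond acceptor, without a step beyond the scatter. Nothing available explains why these exchanges leave the numbers within the scatter.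

On these data alone, it remains open whether any group on this aromatic nitrogen can produce a step beyond the scatter, for example a carboxylic acid, a morpholine ring or a longer alkyl chain. The three compounds also share a single core, so they cannot show whether the same exchanges would stay within the scatter with a different group on the sulfonamide nitrogen.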